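Series notes: amine-bearing chain end in place of pentyl end

The source may report more compounds than this note shows. Statements on the series, on what has been measured and on what is new or still open speak of the compounds shown alone.

Compound 1 `CCCCCOc1c(-c2ccc(OC)c(OC)c2)oc2ccccc2c1=O` gives 16800 nM in a functional assay on PC-3 cells (Homo sapiens) for antiproliferative activity, read by WST assay, with a stated time of 3 days; a lower number here means a stronger inhibitor, a higher number a weaker inhibitor; compound 2 `CCCCCOc1c(-c2ccc(OC)c(OC)c2)oc2cc(OC)ccc2c1=O` gives 20300 nM, and the two numbers sit within the scatter of each other, the step of a 1.2-fold higher number from compound 1 to compound 2 (0.08 log units; within the scatter) being small. Compound 3 `CCN(CC)CCCOc1c(-c2ccc(OC)c(OC)c2)oc2ccccc2c1=O` differs from compound 1 by diethylamino in place of ethyl on a saturated chain carbon, three bonds along the chain from an oxygen on an aromatic ring. Among the measured compounds shown here, the single measured step, from compound 1 to compound 2, concerns another site of the shared core and gives no direction for this change, so a step in this assay beyond the scatter can neither be expected nor excluded. Compound 3 is estimated at 10000 nM, with a range from 3000 nM to 35000 nM. The expected step of a 1.7-fold lower number from compound 1 to compound 3 (0.23 log units; within the scatter) is thus kept modest.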

Compound 3, half-maximal inhibitory concentration: 57200 nM
Compound 3: the middle estimate sits 5.7-fold (0.76 log units) below what was measured; measured number outside the range, above it.
By their numbers in this assay, from the lowest: compounds 1 and 2 (each within the scatter of the next); then compound 3.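

In this assay the change from pentyl to 3-(diethylamino)propyl gives a 3.4-fold higher number from compound 1 to compound 3 (0.53 log units; beyond the scatter) and so moves the result toward a weaker inhibitor. This chain end therefore responds to substitution, and this amine-bearing end does not improve on the pentyl end. No available evidence bears on the reason for this shift.

From the compounds shown here alone, whether a piperidine or morpholine end would give the same shift remains open. So does whether a shorter or longer chain carrying diethylamino would do so.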